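A few compounds are considered here, and "the series" means these few. Any claim that something is new, unique, unknown or untested is made for them only; others in the source may bear on it.

Among the compounds with values here, compound 2 `O=C(O)CCc1ccc(C#Cc2cccc(C(F)(F)F)c2)cc1` gives 89.1 nM in an in vitro functional assay on 1321-N1 cells for agonist activity at Free fatty acid receptor 1 (Homo sapiens), read by fluorescence (on this read-out lower numbers stand for an effect already at smaller amounts and higher numbers for an effect only at larger amounts of compound), the lower of the two numbers measured so far. Within the data shown here, its nearest neighbour is compound 1 `O=C(O)CCc1ccc(C#Cc2cccc(CO)c2)cc1`, which gives 891 nM in this assay; the only measured step, a 10-fold lower number from compound 1 to compound 2 (1.00 log units; beyond the scatter), came from putting trifluoromethyl in place of hydroxymethyl on an aromatic carbon. Compound 3 `N#Cc1cccc(C#Cc2ccc(CCC(=O)O)cc2)c1` differs from compound 2 at that same carbon: cyano in place of trifluoromethyl on an aromatic carbon, cyano in place of trifluoromethyl. Among the measured compounds shown here, the one step on record bears only loosely on this change, since it exchanged a group with one hydrogen-bond donor for one with none, whereas here a group with no acceptors gives way to one with a single acceptor, and cyano itself has not been tried. With so thin a record, the expectation is a modest rise in the number for compound 3 in this assay, but with wide uncertainty either way, so that an expected step of a 3.4-fold higher number from compound 2 to compound 3 (0.53 log units; beyond the scatter) is the best guess. Compound 3 is therefore estimated at 300 nM, with a likely range from 80 nM to 1100 nM.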

Compound 3, half-maximal effective concentration: 91.2 nM
Compound 3: the middle estimate sits 3.3-fold (0.52 log units) above what was measured, and the stated range covers the measured number.
By their numbers in this assay, from the lowest: compounds 2 and 3 (each within the scatter of the next); then compound 1.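

At this aromatic carbon, trifluoromethyl (4 heavy atoms, 0 hydrogen-bond acceptors) and cyano (2 heavy atoms, 1 hydrogen-bond acceptor) cannot be told apart in this assay (a 1.0-fold higher number from compound 2 to compound 3 (0.01 log units; within the scatter)), so this difference in heavy atoms and acceptors leaves the number within the scatter for this pair. The comparison with the third group gives a 9.8-fold lower number from compound 1 to compound 3 (0.99 log units; beyond the scatter), which shows that the earlier gain over hydroxymethyl is not confined to trifluoromethyl: among these three compounds, hydroxymethyl is the one that stands apart, while the two other groups sit together at the lower numbers. Nothing on hand explains why cyano and trifluoromethyl match here or why hydroxymethyl differs.

Three groups at a single carbon cannot show which feature of hydroxymethyl goes with its higher number, and a methoxy group, a chlorine atom or an amine at this carbon could help to separate the possibilities. Going by these compounds, it also remains open whether cyano and trifluoromethyl would still match at another carbon of this ring or with a longer chain in place of the propanoic acid.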